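Acyl group size and growth inhibition in the shared core

The source may report more compounds than this note shows. Statements on the series, on what has been measured and on what is new or still open speak of the compounds shown alone.

Measured compounds in this assay:
compound 1 `O=C(Nc1cc(C(F)(F)F)cc(C(F)(F)F)c1)C1CCc2ccccc2N1C(=O)c1ccccc1Cl` gives 2080 nM
compound 2 `O=C(Nc1ccc(C(F)(F)F)cc1)C1CCc2ccccc2N1` gives 25800 nM
compound 3 `CC(=O)N1c2ccccc2CCC1C(=O)Nc1cc(C(F)(F)F)cc(C(F)(F)F)c1` gives > 70000 nM

Compound 3 stands at the edge of what a functional assay on NCI-H23 cells (Homo sapiens) for cytotoxicity, read by sulforhodamine B assay, with a stated time of 72 h (on this read-out higher numbers stand for weaker inhibition of growth and lower numbers for stronger inhibition of growth), reports: its value is a limit of the assay and not a number. Compound 1 carries the lowest number of the three in this assay. Compound 2 differs from compound 1 and from compound 3 in more than one place, so its value is noted without a step. Among the measured compounds shown here, the only measured step that reaches compound 3 is an at least 33-fold higher number from compound 1 to compound 3 (1.52 log units; beyond the scatter); its true size is open because of the limit of > 70000 nM in this assay, at which 1 of the 3 values shown sits.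

Compound 4 `CCCC(=O)N1c2ccccc2CCC1C(=O)Nc1cc(C(F)(F)F)cc(C(F)(F)F)c1` is not yet measured. It differs from compound 3 by ethyl in place of hydrogen on a saturated chain carbon bound to a carbonyl carbon. For the measured compounds named here, the measured step removed an aryl group from the carbonyl carbon and put a methyl there; the step to compound 4 only lengthens that methyl, a much smaller change, and no measured pair shows a change of this kind. A modest gain at most is expected, with a real chance that the assay again reports only a limit. For compound 4 the estimate is 50000 nM, between 12000 nM and 90000 nM, which means an expected step of an at least 1.4-fold lower number from compound 3 to compound 4 (0.14 log units; that floor lies within the scatter).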

Compound 4, concentration for 50% growth inhibition: 15000 nM
Beside the measured number, compound 4's estimate is 3.3-fold (0.52 log units) above it; measured number inside the range.
By their numbers in this assay, from the lowest: compound 1; then compounds 4 and 2 (each within the scatter of the next). At a limit, above all of these: compound 3.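

In this assay this position responds to a change that stays within saturated chains: ethyl in place of hydrogen on a saturated chain carbon bound to a carbonyl carbon gives an at least 4.6-fold lower number from compound 3 to compound 4 (0.66 log units; beyond the scatter), something the earlier exchange of an aryl group for methyl could not show. On these data alone, compound 3 carries a limit of the assay and not a number, so the true size of this step stays open because of that limit: the limit of > 70000 nM in this assay, at which 1 of the 4 values shown sits. Exchanging the 2-chlorophenyl group for the propyl chain still leaves a 7.2-fold higher number from compound 1 to compound 4 (0.86 log units; beyond the scatter), so among these compounds the propyl chain makes up only part of the distance between the methyl and 2-chlorophenyl groups.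

As far as these compounds go, whether a longer chain such as butyl, a branched chain such as isopropyl or an unsubstituted phenyl on the carbonyl carbon would bring the number closer to that of compound 1 remains open. From the compounds shown here alone, compound 2 differs from the other compounds in more than one place, so the contribution of the acyl group relative to no acyl group on the shared core also remains open.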